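This account rests on a few compounds, and the source may have more. Where it says the series, first, only, none or still open, it means among the compounds named here.

Compound 1 (`CN(C)S(=O)(=O)c1cc(C(=O)O)ccc1NCCC(C)(C)C`) and compound 2 (`CN(C)S(=O)(=O)c1cc(C(=O)O)ccc1NCCCCCC(F)(F)F`) share a core and differ in one place. In an ADME assay on microsomes from liver (Mus musculus) for metabolic stability, tested at 5 uM (a higher number here means that the compound lasts longer, a lower number that the compound disappears faster), compound 1 gives > 1 h, which is a limit of the assay and not a number. Compound 2 gives > 1 h, which is also a limit. As far as these compounds go, compound 2 therefore stands at the limit of > 1 h in this assay, at which 2 of the 2 values shown sit, and its true half-life remains unknown.

Compound 3 (`COCCNc1ccc(C(=O)O)cc1S(=O)(=O)N(C)C`) carries methoxy in place of 4,4,4-trifluorobutyl on a saturated chain carbon, two bonds along the chain from a nitrogen on an aromatic ring. Within the data shown here, the one measured step changes the same stretch of chain, so it is the only guide. It is a step that the two limits leave unreadable from compound 1 to compound 2, and so it offers no size to carry over. No step beyond the usual scatter can therefore be predicted in this assay, in either direction. The expected change is a step that the limit leaves unreadable from compound 2 to compound 3, and this figure is only a rough estimate. Compound 3 is expected to show a half-life of about 1.5 h, with an estimated range from 0.7 h to 4 h.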

Compound 3, half-life in the Mus musculus assay: > 1 h
Compound 3: a limit, no number (the forecaster's own chance of this, stated with the estimate: 70%); the middle value does not contradict the limit.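

In the Mus musculus assay compound 3 gives > 1 h and this is a limit of the assay and not a number. Among these compounds, no step from compound 1 or compound 2 to compound 3 can be read: the limit of > 1 h in the Mus musculus assay, at which 3 of the 3 values shown sit.

In a physicochemical assay for solubility, in phosphate buffer, measured as kinetic solubility, at pH 7.4, tested at 250 uM (a higher number here means a more soluble compound, a lower number a less soluble compound), compound 2 gives 249000 nM and compound 3 gives 237000 nM and the two values lie within the scatter of each other.

The compounds shown leave open how long each of the three actually lasts with these microsomes, and whether changing the chain alters that half-life at all.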